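Arene substituent swap: from compound 3 to compound 4

The compounds below may be only part of what the source reports. "The series", "measured", "known", "first", "only" and "open" are said of these compounds alone.

Three compounds share one core and differ only in a single group on an aromatic carbon. Compound 1 `O=C(O)C1CCN(c2ccccc2)C1` carries hydrogen there; in an assay on cells for inhibition of Palmitoleoyl-protein carboxylesterase NOTUM variant C330S (Homo sapiens), read by fluorescence, with a stated time of 40 min (a higher number here means a weaker inhibitor, a lower number a stronger inhibitor), compound 1 gives 48000 nM. Compound 2 `Cc1cccc(N2CCC(C(=O)O)C2)c1` carries methyl, and in this assay compound 2 gives 49000 nM; a 1.0-fold higher number from compound 1 to compound 2 (0.01 log units; within the scatter). Compound 3 `O=C(O)C1CCN(c2cccc(C(F)(F)F)c2)C1` carries trifluoromethyl, and in this assay compound 3 gives 11000 nM, the lowest of the three numbers: a 4.4-fold lower number from compound 1 to compound 3 (0.64 log units; beyond the scatter) and a 4.5-fold lower number from compound 2 to compound 3 (0.65 log units; beyond the scatter), both beyond the scatter, so compound 3 is the strongest inhibitor measured so far.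

Compound 4 `CC(C)c1cccc(N2CCC(C(=O)O)C2)c1` follows from compound 3 by one change: isopropyl in place of trifluoromethyl on an aromatic carbon. For the measured compounds named here, two measured steps bear on it. The step of a 4.5-fold lower number from compound 2 to compound 3 (0.65 log units; beyond the scatter) shows that putting trifluoromethyl in place of a carbon-only group lowered the number; the step of a 1.0-fold higher number from compound 1 to compound 2 (0.01 log units; within the scatter) shows that methyl on its own did nothing beyond the scatter against hydrogen. Isopropyl, like methyl, is built of carbon only, so giving up trifluoromethyl is expected to cost part of that gain, an expected step of a 2.3-fold higher number from compound 3 to compound 4 (0.36 log units; beyond the scatter), while the larger group leaves room for some of it to remain. Compound 4 is therefore expected to give 25000 nM in this assay, with a range from 10000 nM to 60000 nM.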

Compound 4, half-maximal inhibitory concentration: 57000 nM
Compound 4: middle estimate off by 2.3-fold (0.36 log units), on the low side; low and high end bracket the measured number.
By their numbers in this assay, from the lowest: compound 3; then compounds 1, 2 and 4 (each within the scatter of the next).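

In this assay, isopropyl keeps none of the advantage of trifluoromethyl (a 5.2-fold higher number from compound 3 to compound 4 (0.71 log units; beyond the scatter)), and compound 4 stands level with the methyl compound (a 1.2-fold higher number from compound 2 to compound 4 (0.07 log units; within the scatter)) and the compound carrying hydrogen (a 1.2-fold higher number from compound 1 to compound 4 (0.07 log units; within the scatter)). Hydrogen, methyl and isopropyl on this aromatic carbon therefore form a single group of numbers, so going from one carbon to three in a carbon-only group shifts nothing beyond the scatter, and the lower number of compound 3 goes with trifluoromethyl itself rather than with having any group at this place. No measurement at hand says what sets trifluoromethyl apart from isopropyl on this aromatic carbon.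

Still open, on these data alone, is whether other groups that are not built of carbon only, such as chlorine, methoxy or a nitrile, would also lower the number at this place, or whether trifluoromethyl stands alone. Also open, as far as these compounds go, is whether a second fluorinated group, such as trifluoromethoxy, would take the number lower than trifluoromethyl does on the shared core.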